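Swapping a methylphenyl for a formylphenyl on the shared core

The source may hold more compounds than are shown below. What is called first, only, known or untested is meant among the compounds shown, and "the series" means these compounds.

Of the compounds shown here, two have been measured in a functional assay on SK-MEL-2 cells (Homo sapiens) for inhibition, read by sulforhodamine B assay, with a stated time of 48 h, tested at 10 uM; a higher number here means more inhibition at the concentration tested (going by the name of the read-out), a lower number less inhibition. Compound 1, `O=Cc1ccc(-c2cn3ccnc3c(-c3ccc4ncn(C5CCCCC5)c4c3)n2)cc1`, gives 27.8%. Compound 2, `Cc1cccc(-c2cn3ccnc3c(-c3ccc4ncn(Cc5ccccc5)c4c3)n2)c1`, gives 6.34%. Compound 2 stands lowest of the two numbers; compound 1 is the nearer one, and the gap between them lies beyond the scatter. Going by the values given here, these two compounds differ in more than one place, so no single step between them can be defined; only the two values themselves are known.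

Compound 3, `O=Cc1ccc(-c2cn3ccnc3c(-c3ccc4ncn(Cc5ccccc5)c4c3)n2)cc1`, is not yet measured in this assay. It is reached from compound 2 by one change: 4-formylphenyl in place of 3-methylphenyl on an aromatic carbon. Compound 3 thus carries the same 4-formylphenyl group as compound 1 while keeping the benzyl of compound 2.

The basis for an expectation lies in compound 1, which gives 27.8% with the 4-formylphenyl group in place. On that basis an upward step is expected, a number 11.7 percentage points higher from compound 2 to compound 3 (beyond the scatter), though it may well stay within the scatter. Compound 3 is therefore estimated at 18%, with a range from 4% to 34%.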

Compound 3, a percentage reported as inhibition, at one concentration (the size of the read-out at that concentration, not a potency): 27.8%
For compound 3 the middle estimate is 9.8 percentage points below the measured one, and the stated range covers the measured number.
By their numbers in this assay, from the lowest: compound 2; then compounds 1 and 3 (each within the scatter of the next).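

In this assay, putting 4-formylphenyl in place of 3-methylphenyl on the aromatic carbon of the shared core, with the benzyl held constant, gives a number 21.5 percentage points higher from compound 2 to compound 3 (beyond the scatter) and so shows that the read-out responds to a change at this position, which the first two compounds could not show because they differ in more than one place. Holding 4-formylphenyl constant and putting benzyl in place of cyclohexyl on the aromatic nitrogen gives no change at the digits printed from compound 1 to compound 3 (within the scatter) and so these two groups cannot be told apart in this pair. No measurement shown here gives a reason for either step.

The swap alters both the substituent and its position on the phenyl ring, so the compounds shown cannot say which of the two matters; a 4-methylphenyl or a 3-formylphenyl would separate them. Also open, as far as these compounds go, is how a carboxylic acid or an amine would read in place of the formyl group, and whether benzyl and cyclohexyl would still fall within the scatter of each other alongside 3-methylphenyl.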